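The source may report more compounds than this note shows. Statements on the series, on what has been measured and on what is new or still open speak of the compounds shown alone.

Measured compounds:
- Compound 1, `CCc1ccccc1-c1cc(C(=O)N[C@@H](CCN2CCCCC2)CC(=O)NC2CCC2)nn1C1CCCC1`: 76.5%
- Compound 2, `O=C(C[C@H](CCN1CCCCC1)NC(=O)c1cc(-c2ccccc2Cl)n(C2CCCC2)n1)NC1CCC1`: "nd" (no result reported)
- Compound 3, `CS(=O)(=O)c1ccccc1-c1cc(C(=O)N[C@@H](CCN2CCCCC2)CC(=O)NC2CCC2)nn1C1CCCC1`: "nd" (no result reported)

In an ADME assay on microsomes from liver (Rattus norvegicus, strain Sprague-Dawley) for metabolic stability, read by LC-MS, using NADPH, with a stated time of 30 min, tested at 1 uM (on this read-out higher numbers stand for a more stable compound and lower numbers for a less stable compound), compound 1 gives 76.5%. Compound 2 carries no single number in this assay; its entry reads "nd" (no result reported), and compound 3 likewise stands at "nd" (no result reported), so compound 2 cannot be placed against compound 1 or compound 3 on the numbers at hand.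

The unmeasured compound 4 is `CC(F)(F)c1ccccc1-c1cc(C(=O)N[C@@H](CCN2CCCCC2)CC(=O)NC2CCC2)nn1C1CCCC1`. Its difference from compound 2 is 1,1-difluoroethyl in place of chloro on an aromatic carbon, the 2-chlorophenyl becoming a 2-(1,1-difluoroethyl)phenyl while the rest of the shared core stays as in compound 2.

Going by the values given here, with no number for compound 2 and no measured pair that shows this change, the size and direction of the step in this assay cannot be read from the data; the only anchor is compound 1 at 76.5%. Compound 4 is therefore expected to land near 70%, with a range from 45% to 90%.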

Compound 4, percent of the compound remaining: 77.1%
Estimate against measurement, compound 4: 7.1 percentage points below, within the range that was stated.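

In this assay, the group on this aromatic carbon now has its first readable step, a number 0.6 percentage points higher from compound 1 to compound 4 (within the scatter), so 1,1-difluoroethyl in place of ethyl leaves the two compounds indistinguishable on this read-out. The steps that would link compound 2 or compound 3 to the others cannot be read; neither of them carries a single number. Nothing at hand bears on why the two compounds match.

As far as these compounds go, whether an amine, a carboxylic acid or a longer chain such as propyl on this aromatic carbon would give a similar percent remaining in this assay stays open. So does the comparison of chloro with 1,1-difluoroethyl, and of either with the methylsulfonyl group of compound 3, on this read-out.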